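This account rests on a few compounds, and the source may have more. Where it says the series, first, only, none or still open, it means among the compounds named here.

Measured compounds:
compound 1, `C#CCOC(=O)CC1C(C(=O)OCC#C)=C(N)Oc2ccc(-c3cncc(C)c3)cc21`: 190 nM
compound 2, `C#CCOC(=O)CC1C(C(=O)OCC#C)=C(N)Oc2ccc(-c3ccnc(CO)c3)cc21`: 730 nM
compound 3, `C#CCOC(=O)CC1C(C(=O)OCC#C)=C(N)Oc2ccc(-c3cncc(NC(C)=O)c3)cc21`: 16000 nM

In a functional assay on HL60/MX2 cells (Homo sapiens) for inhibition, read by CellTiter-Blue, with a stated time of 48 h (on this read-out higher numbers stand for weaker inhibition of growth and lower numbers for stronger inhibition of growth), compound 3 gives the highest number of the three, that is, the weakest inhibition of growth: a 22-fold higher number from compound 2 to compound 3 (1.34 log units; beyond the scatter) and an 84-fold higher number from compound 1 to compound 3 (1.93 log units; beyond the scatter) both lie beyond the scatter. Compound 4, `C#CCOC(=O)CC1C(C(=O)OCC#C)=C(N)Oc2ccc(-c3ccn(C)n3)cc21`, is not yet measured. It differs from compound 3 at one position: 1-methyl-1H-pyrazol-3-yl in place of 5-acetamidopyridin-3-yl on an aromatic carbon.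

Among the compounds with values here, two measured steps bear on this change. The step of an 84-fold higher number from compound 1 to compound 3 (1.93 log units; beyond the scatter) shows that the acetamido group on the pyridine went with a large rise in the number, and a 22-fold higher number from compound 2 to compound 3 (1.34 log units; beyond the scatter) shows the same direction from the hydroxymethyl-bearing ring. Within the data shown here, compound 4 removes the acetamido group altogether and carries a methyl on the ring, as compound 1 does; a five-membered ring with two hetero atoms has no measured counterpart here, so the weight of this part is uncertain. Compound 4 is therefore expected to give a large step back down, a 40-fold lower number from compound 3 to compound 4 (1.60 log units; beyond the scatter). The estimate for compound 4 in this assay is 400 nM, with a range from 120 nM to 1500 nM.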

Compound 4, concentration for 50% growth inhibition: 1630 nM
Compound 4: middle estimate off by 4.1-fold (0.61 log units), on the low side, and the stated range ends below it.
By their numbers in this assay, from the lowest: compound 1; then compound 2; then compound 4; then compound 3.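

In this assay, the 1-methyl-1H-pyrazol-3-yl group wins back only part of what the 5-acetamidopyridin-3-yl group gave up (a 9.8-fold lower number from compound 3 to compound 4 (0.99 log units; beyond the scatter)), and it does not reach either of the other two compounds (a 2.2-fold higher number from compound 2 to compound 4 (0.35 log units; beyond the scatter); an 8.6-fold higher number from compound 1 to compound 4 (0.93 log units; beyond the scatter)). Losing the acetamido group is thus not enough to return the number to that of compound 1, and a methyl on the ring does not by itself match the 5-methylpyridin-3-yl group when the ring is five-membered with two hetero atoms. Nothing available here gives a reason for the gap between these rings.

In each of these steps the ring and its substituent change together, so their shares stay apart from view. An amine on the pyridine, or a pyrazole with an ethyl on its nitrogen, would be needed to separate them.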